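The source may report more compounds than this note shows. Statements on the series, on what has been measured and on what is new or still open speak of the compounds shown alone.

Measured compounds in an assay on isolated protein for displacement of a labelled ligand from melanin-concentrating hormone receptor 1 (Homo sapiens); on this read-out higher numbers stand for weaker inhibition and lower numbers for stronger inhibition:

- compound 1 `CCCc1cc(N)c2cc(NC(=O)/C=C/c3ccc(C(C)(C)C)cc3)ccc2n1`: 22 nM
- compound 2 `CCCc1cc(N)c2cc(NC(=O)/C=C/c3ccc(CC)cc3)ccc2n1`: 1.4 nM
- compound 3 `Nc1cc(C2CCC2)nc2ccc(NC(=O)/C=C/c3ccc(C(F)(F)F)cc3)cc12`: 2 nM

Compound 2 gives the lowest number of the three in this assay; compound 3 gives a number that lies within the scatter of it, whereas compound 1 sits well apart, as the step of a 16-fold lower number from compound 1 to compound 2 (1.20 log units; beyond the scatter) shows. That step is the only one measured that bears on the change now considered, and it concerns the same position on the cinnamoyl-type chain: 2-chlorophenyl in place of 4-ethylphenyl on a double-bonded chain carbon bound to a double-bonded chain carbon, giving compound 4 `CCCc1cc(N)c2cc(NC(=O)/C=C/c3ccccc3Cl)ccc2n1`. The measured step tells that the group on this ring is not indifferent, a change of alkyl there moving the number a long way. Nothing measured shows the effect of a chlorine, of placing a substituent at the 2-position of the ring, or of leaving the 4-position bare; compound 3 carries trifluoromethyl on a different core and so gives no clean comparison. The step is therefore expected to be sizeable and more likely toward a higher number, with wide uncertainty: compound 4 is expected at 8 nM (range 1.5 nM to 50 nM), which would mean a 5.7-fold higher number from compound 2 to compound 4 (0.76 log units; beyond the scatter).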

Compound 4, half-maximal inhibitory concentration: 120 nM
Compound 4: the middle estimate sits 15-fold (1.18 log units) below what was measured; the measured number lies above the stated range.
By their numbers in this assay, from the lowest: compounds 2 and 3 (each within the scatter of the next); then compound 1; then compound 4.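

In this assay, an 86-fold higher number from compound 2 to compound 4 (1.93 log units; beyond the scatter) shows that exchanging 4-ethylphenyl for 2-chlorophenyl on this chain is not tolerated, although the trifluoromethyl-bearing ring of compound 3 and the ethyl-bearing ring of compound 2 both stand at low numbers. Among the compounds shown here, with compound 1 at 22 nM and compound 4 at 120 nM, the 2-chlorophenyl group gives a higher number than even the 4-tert-butylphenyl group on the same core, so a bulky alkyl group is not the only change at this position that raises the number. Nothing at hand accounts for this step.

For the compounds shown here, the single step changes the group, its place on the ring and the bare 4-position together, and these cannot yet be separated. Plain phenyl, 4-chlorophenyl and 2-ethylphenyl on the same chain remain open, and they would show which of these changes carries the step.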